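Compound 1 and its ring-opened form, compound 3

A few compounds are considered here, and "the series" means these few. Any claim that something is new, unique, unknown or untested is made for them only; others in the source may bear on it.

In a functional assay on Bel-7402 cells (Homo sapiens) for inhibition, read by MTT assay, with a stated time of 24 h, tested at 100 ug/mL (a lower number here means less inhibition of growth, a higher number more inhibition of growth at the concentration tested), compound 1 `O=C(CCCCC1CCSS1)Nc1ccccn1` gives 37.6% and compound 2 `O=C(CCCCC1CCSS1)Nc1ccc(Br)cn1` gives 45.5%. Going by the values given here, these are the only two measured values, and the step is a number 7.9 percentage points higher from compound 1 to compound 2 (within the scatter), so compound 1 stands level with compound 2 in this assay.

Compound 3 `O=C(CCCCC(S)CCS)Nc1ccccn1` differs from compound 1 by a group of 5 heavy atoms (3 carbon, 2 sulfur; no ring) in place of a group of 5 heavy atoms (3 carbon, 2 sulfur; one five-membered non-aromatic ring with 2 hetero atoms), on a saturated chain carbon, four bonds along the chain from a carbonyl carbon. The five-membered non-aromatic ring gives way to 1,3-disulfanylpropyl, which has no ring, while the core of compound 1 stays unchanged.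

Among the compounds with values here, the single measured step, bromo in place of hydrogen on an aromatic carbon, lies elsewhere in the molecule. It offers no direct guide to the size or direction of this change. Within the data shown here, with no measured precedent, no change beyond the scatter is expected in this assay. The expected result is a number 2.4 percentage points higher from compound 1 to compound 3 (within the scatter). Compound 3 is estimated at 40%, with an expected range of 25% to 55%.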

Compound 3, percent growth inhibition at one concentration: 3.62%
The estimate for compound 3 lay 36.4 percentage points above the measured number, and the stated range ends above it.
By their numbers in this assay, from the lowest: compound 3; then compounds 1 and 2 (each within the scatter of the next).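

Replacing the five-membered non-aromatic ring with 1,3-disulfanylpropyl, on a saturated chain carbon, four bonds along the chain from a carbonyl carbon, gives in this assay a clear change, with a number 34 percentage points lower from compound 1 to compound 3 (beyond the scatter), whereas the bromo step between compound 1 and compound 2 stayed within the scatter. The entering and leaving groups have the same count of heavy atoms, so this position is sensitive to more than that count: the ring is lost and hydrogen-bond donors enter. No measurement here bears on the cause of this step.

The compounds shown leave open whether the fall follows the loss of the ring or the presence of the two free thiol groups. A 1,3-bis(methylsulfanyl)propyl group, which has no ring and carries methyl on each sulfur, would separate these two changes.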